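A Nitrophenyl Arm on the Ester of a Glycoside

The source may hold more compounds than are shown below. What is called first, only, known or untested is meant among the compounds shown, and "the series" means these compounds.

Three compounds have been measured in a functional assay on SK-BR-3 cells (Homo sapiens) for antiproliferative activity, read by MTT assay, with a stated time of 72 h; on this read-out higher numbers stand for weaker inhibition and lower numbers for stronger inhibition:
Compound 1 `C/C=C1/[C@H](O[C@@H]2O[C@H](COC(C)=O)[C@@H](OC(C)=O)[C@H](OC(C)=O)[C@H]2OC(C)=O)OC=C(C(=O)OC)[C@H]1CC(=O)OCCC` gives 6600 nM.
Compound 2 `C/C=C1/[C@H](O[C@@H]2O[C@H](CO)[C@@H](O)[C@H](O)[C@H]2O)OC=C(C(=O)OC)[C@H]1CC(=O)OCC` reaches only the assay limit, > 15000 nM.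
Compound 3 `C/C=C1/[C@H](O[C@@H]2O[C@H](COC(C)=O)[C@@H](OC(C)=O)[C@H](OC(C)=O)[C@H]2OC(C)=O)OC=C(C(=O)O)[C@H]1CC(=O)OCCCCCCCCCCCCCCC` also reaches only a limit, > 20000 nM.

All three share the same core, a cyclic ether bearing a sugar and two ester groups, and differ in the sugar's protecting groups and in the alcohol part of the side-chain ester. Compound 2, with a free sugar and an ethyl ester, stands at the limit of > 15000 nM in this assay, at which 1 of the 3 values shown sits, so for it only a limit and no number is known. Compound 3 stands at the limit of > 20000 nM in this assay, at which 1 of the 3 values shown sits. Compound 1, with its acetylated sugar and propyl ester, is the only one of the three with a measured number.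

Compound 4 `C/C=C1/[C@H](O[C@@H]2O[C@H](CO)[C@@H](O)[C@H](O)[C@H]2O)OC=C(C(=O)OC)[C@H]1CC(=O)OCCc1ccc([N+](=O)[O-])cc1` keeps the free sugar of compound 2 and differs only in the ester: 4-nitrophenyl in place of hydrogen on a saturated chain carbon, two bonds along the chain from an oxygen next to a carbonyl group.

Among the compounds with values here, no step between measured compounds is known, so the size of this change in this assay cannot be read from the data. The expected step of an at least 1.2-fold lower number from compound 2 to compound 4 (0.09 log units; that floor lies within the scatter) is small, if any, and may not rise beyond the scatter. Compound 4 is therefore expected to give about 12000 nM, within 3000 nM to 40000 nM.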

Compound 4, half-maximal inhibitory concentration: > 20000 nM
Compound 4 gave a limit, no number; the forecaster's own chance of this, stated with the estimate: 50%; middle value at least 1.6-fold (0.22 log units) away from the limit.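

In this assay compound 4 gives > 20000 nM and this is a limit, not a number. Within the data shown here, compound 2 is also known only as a limit, so no step between compound 2 and compound 4 can be read. From the compounds shown here alone, how far 4-nitrophenyl in place of hydrogen shifts the read-out, and in which direction, stays open.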